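Swapping 3,5-dimethyl-1,2-oxazol-4-yl for 1-methyl-1H-pyrazol-5-yl

The compounds below may be only part of what the source reports. "The series", "measured", "known", "first", "only" and "open" are said of these compounds alone.

Measured so far in an ADME assay on microsomes from liver (Mus musculus) for metabolic stability, with a stated time of 10 min, tested at 0.5 uM; a higher number here means that more of the compound is left, a lower number that less of the compound is left (values below)
- compound 1 `Cc1noc(C)c1[C@@H]1C[C@@](C)(c2ccc(F)cc2F)N=C(N)S1` gives 72%
- compound 2 `Cc1onc(-c2ccccc2)c1[C@@H]1C[C@@](C)(c2ccc(F)cc2F)N=C(N)S1` gives 12%
- compound 3 `Cc1onc(-c2cccnc2)c1[C@@H]1C[C@@](C)(c2ccc(F)cc2F)N=C(N)S1` gives 6%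

Compound 1 stands highest of the three. Its two steps (a number 60 percentage points lower from compound 1 to compound 2 (beyond the scatter) and a number 66 percentage points lower from compound 1 to compound 3 (beyond the scatter)) put phenyl or pyridin-3-yl in place of methyl on an aromatic carbon, and the remaining step (a number 6 percentage points lower from compound 2 to compound 3 (within the scatter)) stays within the scatter. Compound 4 `Cn1nccc1[C@@H]1C[C@@](C)(c2ccc(F)cc2F)N=C(N)S1` differs from compound 1 otherwise (1-methyl-1H-pyrazol-5-yl in place of 3,5-dimethyl-1,2-oxazol-4-yl on a saturated ring carbon), with 1-methyl-1H-pyrazol-5-yl in place of 3,5-dimethyl-1,2-oxazol-4-yl on a saturated ring carbon. It carries neither phenyl nor pyridin-3-yl, so those large steps bear on it only loosely, and no comparable fall is expected. The expected step is small (a number 6 percentage points lower from compound 1 to compound 4 (within the scatter)). Compound 4 is estimated at 66% (range 42% to 86%).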

Compound 4, percent of the compound remaining: 72%
Beside the measured number, compound 4's estimate is 6 percentage points below it; the measured number falls inside the stated range.
By their numbers in this assay, from the lowest: compounds 3 and 2 (each within the scatter of the next); then compounds 1 and 4 (each within the scatter of the next).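

In this assay, replacing the 3,5-dimethyl-1,2-oxazol-4-yl with 1-methyl-1H-pyrazol-5-yl on the saturated ring carbon gives no change at the digits printed from compound 1 to compound 4 (within the scatter). The earlier compounds shown here changed only a substituent on the 1,2-oxazole, whereas this step exchanges the whole five-membered aromatic ring and shows that the read-out can hold with a different ring at this position. Nothing shown explains why the two rings read alike.

The compounds shown leave open whether phenyl on the pyrazole would bring a fall like that seen on the 1,2-oxazole. They also leave open how a group other than an aromatic ring, such as a carboxylic acid or an amine, would read at this position.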